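Removing the terminal nitrile from the heptenyl-type chain of compound 3

The source may report more compounds than this note shows. Statements on the series, on what has been measured and on what is new or still open speak of the compounds shown alone.

For the measured compounds named here, compound 1 `CSCc1cc(C(C)=O)c(O)cc1OCCCCCCC#N` gives 64% in an assay on isolated protein for binding affinity to leukotriene B4 receptor 1 (Homo sapiens), tested at 1 uM (on this read-out lower numbers stand for less inhibition and higher numbers for more inhibition at the one concentration tested (going by the name of the read-out)), and compound 2 `CC(=O)c1cc(CO)c(OCCCCCCC#N)cc1O` gives 8%; the one recorded step, a number 56 percentage points lower from compound 1 to compound 2 (beyond the scatter), concerns a change at the acetyl-bearing core and not the chain. Compound 3 `C=CCc1cc(C(C)=O)c(O)cc1OCCCCCC#N` gives 41%, standing second of the three numbers, below compound 1 and above compound 2. Compound 4 `C=CCc1cc(C(C)=O)c(O)cc1OCCCCC` differs from compound 3 by hydrogen in place of cyano on a saturated chain carbon, five bonds along the chain from an oxygen on an aromatic ring. Going by the values given here, no measured step removes a cyano group, so there is nothing of direct bearing; the step from compound 1 to compound 2 only shows that a single change here can be large. Compound 4 is therefore estimated, with wide uncertainty, at 33% (range 8% to 58%), a step of a number 8 percentage points lower from compound 3 to compound 4 (within the scatter) that is expected to stay within the scatter.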

Compound 4, a percentage reported as inhibition, at one concentration (the size of the read-out at that concentration, not a potency): 23%
Estimate against measurement, compound 4: 10 percentage points above; the measured number falls inside the stated range.
By their numbers in this assay, from the lowest: compound 2; then compound 4; then compound 3; then compound 1.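

In this assay, for the compounds shown here, the step of a number 18 percentage points lower from compound 3 to compound 4 (beyond the scatter) is the first measured change at the chain rather than the core, and it shows that the chain end is not silent. Losing the cyano group, with its nitrogen and triple bond, costs a modest but real part of the inhibition seen at this one concentration. Compound 4 still retains measurable inhibition without the nitrile.

On these data alone, whether an amine or a carboxylic acid at this chain end would match the cyano group remains open. Nothing shown here explains why the inhibition falls.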